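Compound 3 to compound 4: difluoromethoxy for methyl

A few compounds are considered here, and "the series" means these few. Any claim that something is new, unique, unknown or untested is made for them only; others in the source may bear on it.

In a physicochemical assay for solubility, read by HPLC, in phosphate buffer, with a stated time of 16 h, at pH 6.8 (a higher number here means a more soluble compound, a lower number a less soluble compound), compound 1 `COc1ccc([C@H](C)NC(=O)Cn2nnc3ccccc3c2=O)cc1` gives 15000 nM and compound 2 `C[C@H](NC(=O)Cn1nnc2ccccc2c1=O)c1ccc(Br)cc1` gives 900 nM. Compound 3 `COc1cccc2nnn(CC(=O)N[C@@H](C)c3ccc(C)cc3)c(=O)c12`, at 9300 nM, lies within the scatter of compound 1 and beyond the scatter from compound 2. Compound 4 `COc1cccc2nnn(CC(=O)N[C@@H](C)c3ccc(OC(F)F)cc3)c(=O)c12` carries difluoromethoxy in place of methyl on an aromatic carbon, para to a large group (difluoromethoxy in place of methyl on an aromatic carbon). Going by the values given here, the only measured step is large: a 17-fold lower number from compound 1 to compound 2 (1.22 log units; beyond the scatter), with bromo in place of methoxy on an aromatic carbon. Among the compounds with values here, no measured step involves methyl or difluoromethoxy, so it offers only loose guidance. A moderate move to a lower number is expected, smaller than that measured step. The step expected in this assay is a 2.3-fold lower number from compound 3 to compound 4 (0.37 log units; beyond the scatter). For compound 4 the estimate is 4000 nM, with an expected range of 1200 nM to 11000 nM.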

Compound 4, solubility: 9600 nM
For compound 4 the middle estimate is 2.4-fold (0.38 log units) below the measured one; the range from low to high includes it.
By their numbers in this assay, from the lowest: compound 2; then compounds 3, 4 and 1 (each within the scatter of the next).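

In this assay, difluoromethoxy in place of methyl on an aromatic carbon, para to a large group, gives a 1.0-fold higher number from compound 3 to compound 4 (0.01 log units; within the scatter), so at this position, on the core of compound 3, four heavy atoms in place of one leave the read-out within the scatter. Going by these compounds alone, this differs in size from the one earlier step, a 17-fold lower number from compound 1 to compound 2 (1.22 log units; beyond the scatter), although that step is a different change on the core of compound 1. Nothing available gives a cause for this result.

As far as these compounds go, whether an amine or a carboxylic acid at this position would also leave the solubility read-out within the scatter remains open. So does whether difluoromethoxy would give the same outcome on the core of compound 1.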